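A few compounds are considered here, and "the series" means these few. Any claim that something is new, unique, unknown or untested is made for them only; others in the source may bear on it.

Working notes on the series.

Compound 1 `CCCC(=O)C1=C(C)NC(=O)NC1c1ccoc1` and compound 2 `CC1=C(C(=O)CC(C)C)C(c2ccoc2)NC(=O)N1` share a core; in an assay on membranes from HeLa cells for displacement of a labelled ligand from adenosine receptor A3 (Homo sapiens), read by scintillation counting, with a stated time of 180 min, tested at 1 uM (a lower number here means less inhibition, a higher number more inhibition at the concentration tested (going by the name of the read-out)), compound 1 gives 2% and compound 2 gives 18%. The change between them is methyl in place of hydrogen on a saturated chain carbon bound to two saturated chain carbons and it produced a number 16 percentage points higher from compound 1 to compound 2 (beyond the scatter).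

Compound 3 `CCSC(=O)C1=C(C)NC(=O)NC1c1cccs1` in this assay gives 1%, which sits close to compound 1 but well under compound 2. The difference between the core of compound 3 and the core of compound 1 is not broken down here.

Compound 4 `CC1=C(C(=O)SC(C)C)C(c2cccs2)NC(=O)N1` has not been measured in this assay. It differs from compound 3 by methyl in place of hydrogen on a saturated chain carbon bound to a saturated chain carbon and a sulfur. This is the same kind of change as that from compound 1 to compound 2, though the place differs: there the carbon is bound to two saturated chain carbons, here to a saturated chain carbon and a sulfur. Within the data shown here, only one measured pair shows this change, so the expectation rests on that pair alone. For compound 4 a step of a number 10 percentage points higher from compound 3 to compound 4 (within the scatter) is expected, somewhat smaller than the earlier one because compound 3 starts from 1% on a different core. Compound 4 is estimated at 11%, within 0% to 30%.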

Compound 4, a percentage reported as inhibition, at one concentration (the size of the read-out at that concentration, not a potency): 1%
Estimate against measurement, compound 4: 10 percentage points above; the range from low to high includes it.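

Adding the methyl on a saturated chain carbon bound to a saturated chain carbon and a sulfur gives no change at the digits printed from compound 3 to compound 4 (within the scatter) in this assay, so the gain seen on the other pair does not carry over to this core: the same change on two cores in this assay, a number 16 percentage points higher (beyond the scatter) from compound 1 to compound 2 and no change at the digits printed (within the scatter) from compound 3 to compound 4, 16 percentage points apart, beyond the scatter of two such steps.

In this series, then, the methyl change cannot be treated as a step that transfers from one core to another. The two pairs do not show what sets the difference, since they differ both in the core and in the place of the methyl, and each result rests on a single pair measured at one concentration, which gives no potency.

The compounds shown leave open whether the step on the core of compound 1 would recur on a third core, or with the methyl on a chain bound through sulfur on that core. They also leave open how a longer chain or an amine at this place would read on either core.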